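Swapping the Aryl Group on the Carbonyl Carbon

The source may report more compounds than this note shows. Statements on the series, on what has been measured and on what is new or still open speak of the compounds shown alone.

Two compounds have been measured in a functional assay on SK-OV-3 cells (Homo sapiens) for cytotoxicity, read by sulforhodamine B assay, with a stated time of 48 h, tested at 1 uM; on this read-out lower numbers stand for a stronger effect and higher numbers for a weaker effect at the one concentration tested:

compound 1 `COc1cc(-c2cc(/C=C/C(=O)c3ccc(N)cc3)[nH]n2)cc(OC)c1OC` — 104%
compound 2 `COc1cc(-c2cc(/C=C/C(=O)c3ccc(Cl)c(Cl)c3)[nH]n2)cc(OC)c1OC` — 89%

For the measured compounds named here, compound 2 holds the lowest of the two numbers, and the single measured step, a number 15 percentage points lower from compound 1 to compound 2 (beyond the scatter), is the gap to its only neighbour. Compound 3 `COc1ccc(C(=O)/C=C/c2cc(-c3cc(OC)c(OC)c(OC)c3)n[nH]2)cc1` arises from compound 2 by one change: 4-methoxyphenyl in place of 3,4-dichlorophenyl on a carbonyl carbon. Going by the values given here, the measured step concerns the same carbonyl carbon but a different pair of groups, so it shows only that an exchange at this position can shift the read-out modestly. Among the compounds with values here, there is no measured compound carrying a 4-methoxyphenyl group here, so the direction is uncertain, and a step no larger than the scatter, or a little beyond it, seems most plausible. Compound 3 is therefore expected to give about 95%, with a range from 78% to 112%. The step this estimate implies is a number 6 percentage points higher from compound 2 to compound 3 (within the scatter), which is expected to stay close to the scatter.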

Compound 3, a percentage reported as activity, at one concentration (the size of the read-out at that concentration, not a potency): 98%
The estimate for compound 3 lay 3 percentage points below the measured number; the range from low to high includes it.
By their numbers in this assay, from the lowest: compounds 2, 3 and 1 (each within the scatter of the next, the first and the last beyond it).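

In this assay, 4-methoxyphenyl on the carbonyl carbon can be told apart from neither earlier aryl group: the exchange for 3,4-dichlorophenyl gives a number 9 percentage points higher from compound 2 to compound 3 (within the scatter), and methoxy in place of amino gives a number 6 percentage points lower from compound 1 to compound 3 (within the scatter). Compound 3 therefore lies within the scatter of both neighbours, although those two lie beyond the scatter of each other, so it adds no clear step at this position and does not show which of them it truly resembles. No measured information on these compounds offers an explanation for these numbers.

The compounds shown leave open whether a phenyl ring carrying a carboxylic acid or a hydroxy group on this carbonyl carbon would give a number clearly apart from these three. They also leave open whether any aryl group here can give a large effect at this single concentration.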